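Adding a Hydroxyalkyl Oxadiazole to a Benzylamide Inhibitor

The source may hold more compounds than are shown below. What is called first, only, known or untested is meant among the compounds shown, and "the series" means these compounds.

Compound 1 `O=C(NCc1ccccc1)c1ccc(-c2ccccc2)nc1` gives 1230 nM in an assay on isolated protein for inhibition of Hematopoietic prostaglandin D synthase (Homo sapiens), read by ELISA; a higher number here means a weaker inhibitor, a lower number a stronger inhibitor.
Compound 2 `O=C(NCc1ccccc1)c1ccc(-c2ccccn2)nc1` gives 453 nM in this assay.
Compound 3 `O=C(NCc1ccccc1)c1cnc(-c2ccccc2)nc1` gives 23.9 nM in this assay.

Compound 2 stands second highest of the three numbers in this assay: its nearest neighbour is compound 1, and compound 3 lies well away with a much lower number. Within the data shown here, the only step measured in one place is a 2.7-fold lower number from compound 1 to compound 2 (0.43 log units; beyond the scatter), which concerns the ring on the core and not the benzyl side. Compound 4 `CC(C)(O)c1nc(-c2cccc(CNC(=O)c3ccc(-c4ccccn4)nc3)c2)no1` differs from compound 2 by 5-(1-hydroxy-1-methylethyl)-1,2,4-oxadiazol-3-yl in place of hydrogen on an aromatic carbon. Among the measured compounds shown here, no measured step touches this position, so the direction of the change cannot be read from the data; the substituent is large and brings a hydrogen-bond donor and several acceptors, which in this set has no precedent. Compound 4 is therefore expected to land near compound 2, with a modest improvement as the more likely outcome, a step of a 1.8-fold lower number from compound 2 to compound 4 (0.26 log units; within the scatter) in this assay. Compound 4 is estimated at 250 nM, within a range of 60 nM to 1000 nM.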

Compound 4, half-maximal inhibitory concentration: 328 nM
For compound 4 the middle estimate is 1.3-fold (0.12 log units) below the measured one; low and high end bracket the measured number.
By their numbers in this assay, from the lowest: compound 3; then compounds 4 and 2 (each within the scatter of the next); then compound 1.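

On an aromatic carbon of the six-membered aromatic ring of carbon only, meta to a large group, 5-(1-hydroxy-1-methylethyl)-1,2,4-oxadiazol-3-yl gives a 1.4-fold lower number from compound 2 to compound 4 (0.14 log units; within the scatter) in this assay, so this substituent of 9 heavy atoms leaves the reading indistinguishable from that of the unsubstituted parent. The earlier step, a 2.7-fold lower number from compound 1 to compound 2 (0.43 log units; beyond the scatter), concerned the ring on the core and said nothing about this position, which now has one measured substituent. No measurement available here accounts for this result.

Going by these compounds, whether the hydroxyl group of the substituent matters remains open, and a simple 5-methyl-1,2,4-oxadiazol-3-yl group would address that question. Also open, on these data alone, is how a carboxylic acid or an aminomethyl group on the same carbon would read in this assay, and whether the substituent would behave alike on the core of compound 3.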